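The source may report more compounds than this note shows. Statements on the series, on what has been measured and on what is new or still open speak of the compounds shown alone.

Measured so far in an assay on isolated protein for inhibition of serine/threonine-protein kinase TNNI3K (Homo sapiens); a lower number here means a stronger inhibitor, a higher number a weaker inhibitor:
Compound 1 `CCc1cc(NC(=O)Nc2cccc(C(F)(F)F)c2)cc(Cl)c1Oc1cc(NC)ncn1` gives <= 10 nM, which is a limit of the assay rather than a number.
Compound 2 `CNc1cc(Oc2ccc(NC(=O)Nc3cccc(CF)c3)cc2)ncn1` gives 400 nM.
Compound 3 `COc1cc(Oc2ccc(NC(=O)Nc3cccc(C(F)(F)F)c3)cc2)ncn1` gives 4000 nM.

Of the two values that are actual numbers, compound 2 holds the lower one; the gap up to compound 3 lies beyond the usual scatter of this assay. Compound 4 `CNc1cc(Oc2ccc(NC(=O)Nc3cccc(C(C)(C)C)c3)cc2)ncn1` has not yet been measured. Compared with compound 2 it carries tert-butyl in place of fluoromethyl on an aromatic carbon. Among the compounds with values here, no pair of measured compounds shows this change alone, so the direction is open. A modest step toward a lower number, no larger than just beyond the scatter, is expected from compound 2 to compound 4, a 2.0-fold lower number from compound 2 to compound 4 (0.30 log units; within the scatter). Compound 4 is therefore estimated at 200 nM, within a range of 50 nM to 1500 nM.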

Compound 4, half-maximal inhibitory concentration: 40 nM
Compound 4: the middle estimate sits 5.0-fold (0.70 log units) above what was measured; measured number below the stated range.
By their numbers in this assay, from the lowest: compound 4; then compound 2; then compound 3. At a limit, below all of these: compound 1.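

Replacing fluoromethyl with tert-butyl on this aromatic carbon gives a 10-fold lower number from compound 2 to compound 4 (1.00 log units; beyond the scatter) in this assay. Within the data shown here, this is the first pair of compounds that differ only here, and it shows that the number responds clearly to the group at this position. A group with more heavy atoms and no fluorine is accepted there, and with a stronger result.

This single step cannot separate the added carbons from the lost fluorine. How a cyclopropyl ring or an amine at this carbon would behave stays open, and any further drop can be followed only so far: the limit of <= 10 nM in this assay, at which 1 of the 4 values shown sits.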